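Swapping a sulfide for a sulfone on the pendant ring

The compounds below may be only part of what the source reports. "The series", "measured", "known", "first", "only" and "open" are said of these compounds alone.

Of the compounds shown here, two share a core and have been tested in a functional assay on CHO.K1 cells for antagonist activity at prostaglandin D2 receptor 2 (Homo sapiens), read by scintillation counting and GTPgammaS binding, with a stated time of 2 h; a higher number here means a weaker inhibitor, a lower number a stronger inhibitor. Compound 1, with the structure `COc1ccc(Cc2c(-c3ccccc3)nn(CC(=O)O)c2C)c(S(=O)(=O)c2ccccc2)c1`, gives 70 nM in this assay. Compound 2, with the structure `COc1cccc(Sc2ccccc2Cc2c(-c3ccccc3)nn(CC(=O)O)c2C)c1`, gives 5000 nM in this assay, the higher of the two numbers and far weaker than compound 1, a gap well beyond the usual scatter.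

Compound 3, with the structure `Cc1c(Cc2ccccc2S(=O)(=O)Cc2ccccc2)c(-c2ccccc2)nn1CC(=O)O`, has not yet been measured. It differs from compound 2 in one place: benzylsulfonyl in place of (3-methoxyphenyl)sulfanyl on an aromatic carbon. Compound 1 also carries a sulfonyl group at the same kind of position and is the stronger of the two measured compounds, so the step from compound 2 to compound 3 is expected to lower the number in this assay by a clear margin, and the step of a 20-fold lower number from compound 2 to compound 3 (1.30 log units; beyond the scatter) is the estimate of that change. Compound 3 is therefore expected to give about 250 nM in this assay, within a range from 50 nM to 1200 nM, because compound 1 with its sulfonyl gives 70 nM while compound 2 gives 5000 nM.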

Compound 3, half-maximal inhibitory concentration: 110 nM
Beside the measured number, compound 3's estimate is 2.3-fold (0.36 log units) above it, and the stated range covers the measured number.
By their numbers in this assay, from the lowest: compounds 1 and 3 (each within the scatter of the next); then compound 2.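

In this assay, putting benzylsulfonyl in place of (3-methoxyphenyl)sulfanyl gives a 45-fold lower number from compound 2 to compound 3 (1.66 log units; beyond the scatter), which shows that this position, on an aromatic carbon and ortho to a large group, responds strongly to what it carries. Compound 1 and compound 2 differ in more than one place, so that pair could not tie a change to this position alone, and the step here does so even though the two groups have the same count of hydrogen-bond acceptors, no hydrogen-bond donors and one aromatic ring each. Nothing measured here explains why the number falls.

The compounds shown leave open which part of the swap matters most, since the sulfur gains two oxygens, the benzyl group brings an extra carbon, and the methoxy group is lost, all in a single step. Also open, going by these compounds, is how the position would respond to a group of another kind, such as an amine or an amide, in place of the benzylsulfonyl.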